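From Bromo to Nitro: What Compound 4 Is Expected to Show

This account rests on a few compounds, and the source may have more. Where it says the series, first, only, none or still open, it means among the compounds named here.

Compound 1 `CCCCCCCCCCCOc1ccccc1C(SCCC(=O)O)SCCC(=O)O`: 287 nM
Compound 2 `CCCCCCCCCCCOc1ccc(OC)cc1C(SCCC(=O)O)SCCC(=O)O`: 579 nM
Compound 3 `CCCCCCCCCCCOc1ccc(Br)cc1C(SCCC(=O)O)SCCC(=O)O`: 624 nM

Of the compounds shown here, three sharing one core have been measured in an assay on membranes from lung (Cavia porcellus) for binding affinity to cysteinyl leukotriene receptor (Homo sapiens); on this read-out higher numbers stand for weaker inhibition and lower numbers for stronger inhibition. Compound 3 carries the highest of the three numbers, but its gap to compound 2 is within the scatter, so the two cannot be ranked against each other. Against compound 1 the gap is real: a 2.2-fold higher number from compound 1 to compound 3 (0.34 log units; beyond the scatter).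

Compound 4 `CCCCCCCCCCCOc1ccc([N+](=O)[O-])cc1C(SCCC(=O)O)SCCC(=O)O` is not yet measured. It differs from compound 3 in one place: nitro in place of bromo on an aromatic carbon.

Within the data shown here, three measured steps bear on this change, all at the same aromatic carbon. Putting a methoxy where hydrogen stood gave a 2.0-fold higher number from compound 1 to compound 2 (0.30 log units; within the scatter). Putting a bromo there gave a 2.2-fold higher number from compound 1 to compound 3 (0.34 log units; beyond the scatter). Exchanging one group for the other gave a 1.1-fold higher number from compound 2 to compound 3 (0.03 log units; within the scatter). In other words, each group at this position nudged the number modestly upward, and trading one group for another left it essentially unchanged. A nitro in place of bromo is another such trade, so the step of a 1.0-fold higher number from compound 3 to compound 4 (0.02 log units; within the scatter) is expected to stay within the scatter, with no clear direction.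

On that basis compound 4 is estimated at 650 nM in this assay, within a range from 300 nM to 1400 nM.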

Compound 4, inhibition constant: 303 nM
Beside the measured number, compound 4's estimate is 2.1-fold (0.33 log units) above it; low and high end bracket the measured number.
By their numbers in this assay, from the lowest: compounds 1, 4, 2 and 3 (each within the scatter of the next, the first and the last beyond it).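

Bromo and nitro are not interchangeable at this aromatic carbon: in this assay the exchange gives a 2.1-fold lower number from compound 3 to compound 4 (0.31 log units; beyond the scatter) and is the first trade between two groups here to go beyond the scatter, though only modestly. The earlier compounds shown here suggested that any group at this carbon might move the number up from that of compound 1, but compound 4 goes against this, with a 1.1-fold higher number from compound 1 to compound 4 (0.02 log units; within the scatter) leaving it level with the unsubstituted compound within the scatter; the same holds for the methoxy compound, with a 1.9-fold lower number from compound 2 to compound 4 (0.28 log units; within the scatter) also within the scatter, so nitro cannot be ranked against either hydrogen or methoxy here. What sets nitro apart from bromo at this position cannot be said, as no measurement in hand explains the difference.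

The compounds shown leave open how an amine or a carboxylic acid at this same carbon would compare with hydrogen, methoxy, bromo and nitro. They also leave open whether the gap between bromo and nitro would persist on a core with a shorter chain in place of the long one.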